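Three Close Values and One Untested Chlorine

The source may hold more compounds than are shown below. What is called first, only, known or untested is meant among the compounds shown, and "the series" means these compounds.

Values from a functional assay on UACC-62 cells (Homo sapiens) for cytotoxicity, read by sulforhodamine B assay (a higher number here means a weaker inhibitor of growth, a lower number a stronger inhibitor of growth), are as follows
compound 1 `COc1ccc(/C=N\NC(=S)NC(C)(C)CCC[C@](C)(O)[C@@H]2CC=C(C)CC2)cc1` gives 7420 nM
compound 2 `CC1=CC[C@@H]([C@@](C)(O)CCCC(C)(C)NC(=S)N/N=C\c2ccc(O)cc2)CC1` gives 8870 nM
compound 3 `CC1=CC[C@@H]([C@@](C)(O)CCCC(C)(C)NC(=S)N/N=C\c2ccccc2[N+](=O)[O-])CC1` gives 6050 nM

Compound 3 stands level with the other two compounds. The steps to it (a 1.2-fold lower number from compound 1 to compound 3 (0.09 log units; within the scatter) and a 1.5-fold lower number from compound 2 to compound 3 (0.17 log units; within the scatter)) both lie within the usual scatter, so its 6050 nM cannot be ranked against them. The remaining step (a 1.2-fold higher number from compound 1 to compound 2 (0.08 log units; within the scatter)) is also within the scatter.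

Compound 4 `CC1=CC[C@@H]([C@@](C)(O)CCCC(C)(C)NC(=S)N/N=C\c2ccc(Cl)cc2)CC1` differs from compound 3 by a single exchange (4-chlorophenyl in place of 2-nitrophenyl on a carbon with a double bond to nitrogen). The two steps to compound 3 are the closest guide, as each also exchanges the aromatic group on that carbon. Among the measured compounds shown here, neither moved the number beyond the scatter, but no measured compound yet carries a chlorine, so the guide is only partial. No step beyond the scatter is therefore expected in this assay here. The estimated step is small (a 1.1-fold higher number from compound 3 to compound 4 (0.03 log units; within the scatter)). For compound 4 the expected value is 6500 nM with an estimated range from 3500 nM to 11000 nM in this measurement.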

Compound 4, concentration for 50% growth inhibition: 7350 nM
Estimate against measurement, compound 4: 1.1-fold (0.05 log units) below; the measured number falls inside the stated range.
By their numbers in this assay, from the lowest: compounds 3, 4, 1 and 2 (each within the scatter of the next).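

In this assay, 4-chlorophenyl in place of 2-nitrophenyl on a carbon with a double bond to nitrogen gives a 1.2-fold higher number from compound 3 to compound 4 (0.08 log units; within the scatter), so a chlorine-bearing ring also stays within the scatter at this position. The same holds for chloro in place of hydroxy, with a 1.2-fold lower number from compound 2 to compound 4 (0.08 log units; within the scatter), and for chloro in place of methoxy, with a 1.0-fold lower number from compound 1 to compound 4 (0.00 log units; within the scatter), which extends the flat picture from three aromatic groups to four. No measurement shown here offers an explanation for this flatness.

From the compounds shown here alone, whether an amine or a carboxylic acid on the aromatic ring would move the number beyond the scatter remains open. Going by these compounds, all four compounds also share one core, so the effect of a change there, such as a longer chain, remains unknown too.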